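The compounds below may be only part of what the source reports. "The series", "measured", "known", "first", "only" and "open" are said of these compounds alone.

Measured in a functional assay on MCF7 cells (Homo sapiens) for inhibition, read by MTT assay, with a stated time of 48 h; a higher number here means a weaker inhibitor, a lower number a stronger inhibitor:
compound 1 `COc1cc(/C=C/C(=O)NO)ccc1OCC(=O)Nc1ccccc1F`: > 100000 nM
compound 2 `COc1cc(/C=C/C(=O)Nc2ccccc2N)ccc1OCC(=O)Nc1cccc(F)c1`: > 100000 nM
compound 3 `COc1cc(/C=C/C(=O)Nc2ccccc2N)ccc1OCC(=O)Nc1ccc(Cl)c(Cl)c1`: > 100000 nM

Each entry is a limit of the assay and not a number. The series therefore has no readable potency so far, and the shared position is the limit of > 100000 nM in this assay, at which 3 of the 3 values shown sit.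

Compound 2 stands at > 100000 nM, which is a limit. Compound 3 gives > 100000 nM, also a limit. Within the data shown here, the only measured step is a step that the two limits leave unreadable from compound 2 to compound 3, so it supplies no size to carry forward.

Compound 4 `COc1cc(/C=C/C(=O)NO)ccc1OCC(=O)Nc1cccc(F)c1` has not yet been measured. Its change from compound 2 is hydroxy in place of 2-aminophenyl on an amide-type nitrogen. Among the measured compounds shown here, no measured step covers this exchange directly.

The closest guide is compound 1, which carries hydroxy on an amide-type nitrogen and gives > 100000 nM, a limit, so no step beyond the scatter is expected in this assay. A readable value, if one appears, would be expected on the side of a stronger inhibitor.

The expected step is a number no higher from compound 2 to compound 4 (the limit leaves the size open).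

For compound 4 the estimate is 100000 nM, with an expected range of 25000 nM to 200000 nM.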

Compound 4, half-maximal inhibitory concentration: 39500 nM
The estimate for compound 4 lay 2.5-fold (0.40 log units) above the measured number; low and high end bracket the measured number.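

In this assay, among these compounds, hydroxy in place of 2-aminophenyl on an amide-type nitrogen gives an at least 2.5-fold lower number from compound 2 to compound 4 (0.40 log units; beyond the scatter), the first change with a readable number on one side. The starting value is a limit. The size of this step stays a minimum. With hydroxy held constant, 3-fluorophenyl in place of 2-fluorophenyl on an amide-type nitrogen gives an at least 2.5-fold lower number from compound 1 to compound 4 (0.40 log units; beyond the scatter), so hydroxy alone does not give a readable number and the fluorine position on the phenyl ring also counts in this series. The step between the two 2-aminophenyl compounds cannot be read, and compound 4 remains the only compound with a readable number: the limit of > 100000 nM in this assay, at which 3 of the 4 values shown sit.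

The compounds shown leave open whether the gain from hydroxy depends on the 3-fluorophenyl group, and whether 3,4-dichlorophenyl or another halogen pattern would move the number further with hydroxy in place. They also leave open what a methoxy group or a plain amine on that amide-type nitrogen would give, and so whether the hydroxy group itself is required for a readable number.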